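Swapping the Benzyl Ester Group of a Weak Inhibitor

This account rests on a few compounds, and the source may have more. Where it says the series, first, only, none or still open, it means among the compounds named here.

Within the data shown here, compound 1, `CC(C)(C)OC(=O)N[C@@H](CC(=O)OC1CCCC1)C(=O)OCc1ccc(Cl)cc1`, is one of two compounds measured so far. In a functional assay on IMR-32 cells for inhibition of Voltage-dependent N-type calcium channel subunit alpha-1B (Homo sapiens), read by calcium flux (a higher number here means a weaker inhibitor, a lower number a stronger inhibitor), compound 1 gives 3300 nM. Compound 2, `COc1ccc(CN(C)C(=O)[C@H](COCC2CCCCC2)NC(=O)OC(C)(C)C)cc1`, is built on a different core; in this assay compound 2 gives 1800 nM, and the two numbers lie within the scatter of each other, so neither can be called the stronger or weaker inhibitor. Compound 3, `COc1cccc(COC(=O)[C@H](CC(=O)OC2CCCC2)NC(=O)OC(C)(C)C)c1`, has not yet been measured. It differs from compound 1 in one place: 3-methoxyphenyl in place of 4-chlorophenyl on a saturated chain carbon bound to an oxygen next to a carbonyl group. No measured pair among these compounds shows what such a change does, so there is nothing to point in either direction. The expected step is no change at the digits printed from compound 1 to compound 3 (within the scatter), which is no more than the usual scatter. Compound 3 is therefore expected to give about 3300 nM in this assay, within a range from 1400 nM to 8000 nM.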

Compound 3, half-maximal inhibitory concentration: 3800 nM
Beside the measured number, compound 3's estimate is 1.2-fold (0.06 log units) below it; low and high end bracket the measured number.
By their numbers in this assay, from the lowest: compounds 2, 1 and 3 (each within the scatter of the next, the first and the last beyond it).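

Among these compounds, replacing 4-chlorophenyl with 3-methoxyphenyl on a saturated chain carbon bound to an oxygen next to a carbonyl group gives a 1.2-fold higher number from compound 1 to compound 3 (0.06 log units; within the scatter) in this assay, the first reading of any change at this place. The two groups cannot be told apart here, although they carry different substituents at different ring positions and the entering group counts one hydrogen-bond acceptor where the leaving group counts none. No measurement shown here accounts for this result.

From the compounds shown here alone, the substituent and its ring position differ together in this single step, so their separate contributions remain unknown, and 3-chlorophenyl or 4-methoxyphenyl would be needed to pull them apart. Going by these compounds, it also remains open whether a phenyl ring carrying an amine or a carboxylic acid would read the same at this place.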